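From bromo to thiophen-3-yl: an expected flat step

The compounds below may be only part of what the source reports. "The series", "measured", "known", "first", "only" and "open" are said of these compounds alone.

Compound 1 `CC(C)(C)Cc1c(-c2cc(F)ccc2F)sc(N)c1C(=O)c1ccc(Cl)cc1`: 1%
Compound 2 `CC(C)(C)Cc1c(Br)sc(N)c1C(=O)c1ccc(Cl)cc1`: 1%

Of the compounds shown here, two share the core and have been measured in an assay on CHO cells for displacement of a labelled ligand from adenosine receptor A3 (Homo sapiens), read by scintillation counting, tested at 10 uM; on this read-out lower numbers stand for less inhibition and higher numbers for more inhibition at the one concentration tested (going by the name of the read-out). In this assay compound 1 gives 1%, and compound 2 gives 1%. Among the measured compounds shown here, the one step between them, no change at the digits printed from compound 1 to compound 2 (within the scatter), is the only guide available; it shows that swapping the 2,5-difluorophenyl for bromo left the read-out unchanged. Compound 2 therefore stands level with compound 1, and both sit at the bottom of the read-out.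

Compound 3 `CC(C)(C)Cc1c(-c2ccsc2)sc(N)c1C(=O)c1ccc(Cl)cc1` is not yet measured in this assay. Its difference from compound 2 is thiophen-3-yl in place of bromo on an aromatic carbon. The change is of the same kind as the measured step, a swap of the group on that ring carbon, and that step was flat. The expectation is therefore a step of about a number 2 percentage points higher from compound 2 to compound 3 (within the scatter) from compound 2 to compound 3, which is no change beyond the scatter. Compound 3 is expected to give about 3% in this assay, within a range from -8% to 18%.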

Compound 3, a percentage reported as inhibition, at one concentration (the size of the read-out at that concentration, not a potency): 4%
Compound 3: the middle estimate sits 1 percentage points below what was measured; measured number inside the range.
By their numbers in this assay, from the lowest: compounds 1, 2 and 3 (each within the scatter of the next).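

On the aromatic carbon next to the ring sulfur, putting one five-membered aromatic ring with 1 sulfur where a single bromine atom stood gives a number 3 percentage points higher from compound 2 to compound 3 (within the scatter) in this assay, so the larger group, with its 5 heavy atoms and 1 hydrogen-bond acceptor, does not separate itself from bromo on this read-out. The third pair adds a comparison between two ring substituents, since exchanging one aromatic ring for another gives a number 3 percentage points higher from compound 1 to compound 3 (within the scatter) in this assay, and bromo, 2,5-difluorophenyl and thiophen-3-yl thus cannot be told apart at this position, with all three compounds near the bottom of the read-out. Nothing available gives a reason for this flat picture, which stands here as an observation only.

The compounds shown leave open whether a group of another kind on this ring carbon, such as an amine or a carboxylic acid, would lift the read-out clear of the scatter. They also leave open whether this position would stay as flat if the neopentyl group were replaced by a shorter chain such as ethyl, or if the amino group were replaced by an acetamide.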